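The compounds below may be only part of what the source reports. "The series", "measured", "known", "first", "only" and "open" are said of these compounds alone.

Compound 1 (`O=C(Nc1cccc(-c2ccsc2)c1)C(Cl)Cl`) is the starting point here. In a functional assay on KB 3-1 cells (Homo sapiens) for cytotoxicity, read by MTT assay, with a stated time of 68 h (a lower number here means a stronger inhibitor, a higher number a weaker inhibitor), compound 1 gives > 50000 nM as its reading, and this is a limit of the assay and not a number. In this assay compound 2 (`CCOc1ccccc1-c1cc(NC(=O)C(Cl)Cl)cc(-c2ccccc2OCC)c1`) gives 8730 nM as a true number. Going by the values given here, no two measured compounds differ in only one place, so the data do not size any single change directly.

Compound 3 (`O=C(Nc1cccc(-c2ccccn2)c1)C(Cl)Cl`) has pyridin-2-yl in place of thiophen-3-yl on an aromatic carbon. This swaps one aromatic ring for another and leaves the rest of compound 1 untouched. The expectation rests mainly on compound 1 and the limit of > 50000 nM in this assay, at which 1 of the 2 values shown sits, as the only anchor. Compound 3 is therefore expected to remain a weak inhibitor, with at most a small move towards stronger inhibition. The expected change is an at least 1.2-fold lower number from compound 1 to compound 3 (0.09 log units; that floor lies within the scatter) and it may prove too small to measure. In this assay the estimate for compound 3 is 40000 nM with an expected range from 15000 nM to 90000 nM and a reading that is only a limit is quite likely.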

Compound 3, half-maximal inhibitory concentration: > 50000 nM
Compound 3: only a limit was reported; the forecaster's own chance of this, stated with the estimate: 60%; at least 1.2-fold (0.09 log units) between middle value and limit.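

Compound 1 and compound 3 both end at a limit of this assay and not at a true number, so the step between them cannot be read: the limit of > 50000 nM in this assay, at which 2 of the 3 values shown sit.

Still open, from the compounds shown here alone, is whether thiophen-3-yl or pyridin-2-yl gives the weaker reading, and how large any difference between these two groups might be.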